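Adding an Ethyl Group to the Urea of Compound 3

This account rests on a few compounds, and the source may have more. Where it says the series, first, only, none or still open, it means among the compounds named here.

Compound 1 `NC(=O)N1CCN(C(=S)SCc2cn(Cc3ccccc3F)nn2)CC1` gives 11300 nM in a functional assay on MGC-803 cells (Homo sapiens) for cytotoxicity, read by MTT assay, with a stated time of 72 h; on this read-out lower numbers stand for stronger inhibition and higher numbers for weaker inhibition. Compound 2 `CCNC(=O)N1CCN(C(=S)SCc2cn(Cc3ccccc3F)nn2)CC1`, which carries an ethyl on the urea nitrogen, gives 2830 nM in this assay, a modest gain described by a 4.0-fold lower number from compound 1 to compound 2 (0.60 log units; beyond the scatter). Compound 3 `NC(=O)N1CCN(C(=S)SCc2cn(Cc3ccc(F)cc3)nn2)CC1` gives 9330 nM in this assay; the difference a 1.2-fold lower number from compound 1 to compound 3 (0.08 log units; within the scatter) is within the scatter, while the gap to compound 2 lies beyond it. Compound 4 `CCNC(=O)N1CCN(C(=S)SCc2cn(Cc3ccc(F)cc3)nn2)CC1` has not been measured. It differs from compound 3 by ethyl in place of hydrogen on an amide-type nitrogen, carbamoyl becoming ethylcarbamoyl. Going by the values given here, the one measured step of this kind, a 4.0-fold lower number from compound 1 to compound 2 (0.60 log units; beyond the scatter), was a modest drop beyond the scatter, so a similar lowering is expected here. Compound 4 is therefore estimated at 2400 nM, within the range 1000 nM to 5800 nM, which would mean an expected step of a 3.9-fold lower number from compound 3 to compound 4 (0.59 log units; beyond the scatter).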

Compound 4, half-maximal inhibitory concentration: 2170 nM
Compound 4: the middle estimate sits 1.1-fold (0.04 log units) above what was measured; measured number inside the range.
By their numbers in this assay, from the lowest: compounds 4 and 2 (each within the scatter of the next); then compounds 3 and 1 (each within the scatter of the next).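

In this assay the ethyl gives a 4.3-fold lower number from compound 3 to compound 4 (0.63 log units; beyond the scatter), so the gain seen on the 2-fluorophenyl compounds also appears with 4-fluorophenyl, and the size of the step holds across both cores: the same change on two cores in this assay, a 4.0-fold lower number (0.60 log units; beyond the scatter) from compound 1 to compound 2 and a 4.3-fold lower number (0.63 log units; beyond the scatter) from compound 3 to compound 4, 1.1-fold (0.03 log units) apart, within the scatter of two such steps. Moving from 2-fluorophenyl to 4-fluorophenyl with the ethyl in place gives a 1.3-fold lower number from compound 2 to compound 4 (0.12 log units; within the scatter), and that small step matches the one seen without the ethyl: the same change on two cores in this assay, a 1.2-fold lower number (0.08 log units; within the scatter) from compound 1 to compound 3 and a 1.3-fold lower number (0.12 log units; within the scatter) from compound 2 to compound 4, 1.1-fold (0.03 log units) apart, within the scatter of two such steps. Across these four compounds, the effect of the ethyl does not depend on which fluorophenyl is present.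

The compounds shown leave open whether a longer chain such as butyl, or a phenyl ring, on this nitrogen would lower the number further.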